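Two Limits and a Third Carbonyl Substituent

A few compounds are considered here, and "the series" means these few. Any claim that something is new, unique, unknown or untested is made for them only; others in the source may bear on it.

In a functional assay on Caco-2 cells (Homo sapiens) for antiproliferative activity, read by MTT assay, with a stated time of 48 h (on this read-out lower numbers stand for stronger inhibition and higher numbers for weaker inhibition), compound 1 (`C=CCN(C)C(=O)c1ccc(C(CC)(CC)c2ccc(OCCC(O)(CC)CC)c(C)c2)n1CC`) gives > 50000 nM, which is a limit and not a number. Compound 2 (`C#CCCOC(=O)c1ccc(C(CC)(CC)c2ccc(OCCC(O)(CC)CC)c(C)c2)n1CC`) gives > 50000 nM, which is likewise a limit, so compound 2 has no readable number to start from.

Compound 3 (`CCOC(=O)CN(C)C(=O)c1ccc(C(CC)(CC)c2ccc(OCCC(O)(CC)CC)c(C)c2)n1CC`) differs from compound 2 on a carbonyl carbon, where ((ethoxycarbonyl)methyl)(methyl)amino takes the place of (but-3-yn-1-yl)oxy: ((ethoxycarbonyl)methyl)(methyl)amino in place of (but-3-yn-1-yl)oxy on a carbonyl carbon. Like compound 1, compound 3 carries an amino group on that carbonyl carbon, while the shared core stays the same. Within the data shown here, the only measured step bearing on this change is a step that the two limits leave unreadable from compound 1 to compound 2, and it offers no size to carry over. What the data do show is the limit of > 50000 nM in this assay, at which 2 of the 2 values shown sit. Among the measured compounds shown here, no step of known size can therefore be drawn on for this assay, and no direction can be argued from it, though compound 3 is expected to stay near that limit. The expected step is a number no higher from compound 2 to compound 3 (the limit leaves the size open). Compound 3 is estimated at 50000 nM, with an expected range from 15000 nM to 120000 nM.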

Compound 3, half-maximal inhibitory concentration: 30300 nM
For compound 3 the middle estimate is 1.7-fold (0.22 log units) above the measured one; the measured number falls inside the stated range.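

Among these compounds, compound 3 is the first of the three to give a number rather than a limit in this assay, so this carbonyl carbon now has a readable point of reference. Setting ((ethoxycarbonyl)methyl)(methyl)amino in place of (but-3-yn-1-yl)oxy gives an at least 1.6-fold lower number from compound 2 to compound 3 (0.21 log units; that floor lies within the scatter), and ethoxycarbonyl in place of vinyl on a saturated chain carbon bound to an amide-type nitrogen gives an at least 1.6-fold lower number from compound 1 to compound 3 (0.21 log units; that floor lies within the scatter). Neither floor is shown to go beyond the scatter, and the set as a whole still rests mostly on a single limit: the limit of > 50000 nM in this assay, at which 2 of the 3 values shown sit.

As far as these compounds go, the values of compound 1 and compound 2 are limits and not numbers, and the true size of both steps stays open. Also open, from the compounds shown here alone, is whether a carboxylic acid in place of the ethoxycarbonyl group, or a longer chain between that group and the amide-type nitrogen, would move the number in this assay at all.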